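Adding a Nitrile Where Solubility Was Lowest

The compounds below may be only part of what the source reports. "The series", "measured", "known", "first", "only" and "open" are said of these compounds alone.

Compound 3 `OC[C@H]1O[C@H](Oc2ccc(-c3ccccc3)cc2Cl)[C@@H](O)[C@@H](O)[C@@H]1O` gives 5.5 ug/mL in a physicochemical assay for solubility, measured as kinetic solubility, with a stated time of 15 h, at pH 7.4 (a higher number here means a more soluble compound, a lower number a less soluble compound), the lowest of the three measured numbers; compound 1 `OC[C@H]1O[C@H](Oc2ccc(-c3ccccc3Cl)cc2Cl)[C@@H](O)[C@@H](O)[C@@H]1O` gives 28 ug/mL and compound 2 `N#Cc1ccc(-c2ccc(O[C@H]3O[C@H](CO)[C@@H](O)[C@H](O)[C@@H]3O)c(Cl)c2)cc1` gives 192 ug/mL. Compound 4 `N#Cc1cccc(-c2ccc(O[C@H]3O[C@H](CO)[C@@H](O)[C@H](O)[C@@H]3O)c(Cl)c2)c1` differs from compound 3 by cyano in place of hydrogen on an aromatic carbon. The most relevant measured step runs the opposite way: a 35-fold lower number from compound 2 to compound 3 (1.54 log units; beyond the scatter). The two further steps, a 6.9-fold higher number from compound 1 to compound 2 (0.84 log units; beyond the scatter) and a 5.1-fold lower number from compound 1 to compound 3 (0.71 log units; beyond the scatter), also involve this group and point the same way. In compound 4 the cyano group stands meta to a large group, a different placement from compound 2, so a clear but somewhat smaller rise is expected, a 22-fold higher number from compound 3 to compound 4 (1.34 log units; beyond the scatter). Compound 4 is therefore estimated at 120 ug/mL, within a range from 40 ug/mL to 350 ug/mL.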

Compound 4, solubility: 227 ug/mL
The estimate for compound 4 lay 1.9-fold (0.28 log units) below the measured number, and the stated range covers the measured number.
By their numbers in this assay, from the lowest: compound 3; then compound 1; then compounds 2 and 4 (each within the scatter of the next).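

In this assay, the nitrile brings a large gain in this new placement as well, with compound 4 far above compound 3 (a 41-fold higher number from compound 3 to compound 4 (1.62 log units; beyond the scatter)). The 3-cyanophenyl and 4-cyanophenyl groups cannot be told apart here (a 1.2-fold higher number from compound 2 to compound 4 (0.07 log units; within the scatter)), so in these compounds the gain holds in either placement. The 3-cyanophenyl group also stands clearly above the 2-chlorophenyl group (an 8.1-fold higher number from compound 1 to compound 4 (0.91 log units; beyond the scatter)).

No measurement offered here explains why the nitrile goes with higher numbers. Going by these compounds, whether an amine or a carboxylic acid in the same place would match the nitrile remains open.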